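Adding a chloro group to compound 3

The source may hold more compounds than are shown below. What is called first, only, known or untested is meant among the compounds shown, and "the series" means these compounds.

compound 1 `COc1cc(/C=C/c2ccccc2)c(-c2ccccc2)c(OC)c1OC`: 63000 nM
compound 2 `C=C(c1ccc(OC)cc1)c1cc(OC)c(OC)c(OC)c1-c1ccccc1`: 31000 nM
compound 3 `C=C(c1ccccc1)c1cc(OC)c(OC)c(OC)c1-c1ccccc1`: 34000 nM

In a functional assay on SK-N-SH cells (Homo sapiens) for cytotoxicity, read by MTT assay, with a stated time of 48 h (a lower number here means a stronger inhibitor, a higher number a weaker inhibitor), compound 3 stands within the scatter of both other compounds, with a 1.9-fold lower number from compound 1 to compound 3 (0.27 log units; within the scatter). Compound 4 `C=C(c1ccc(Cl)cc1)c1cc(OC)c(OC)c(OC)c1-c1ccccc1`, not yet measured, carries chloro in place of hydrogen on an aromatic carbon, para to a large group (chloro in place of hydrogen on an aromatic carbon). Among the compounds with values here, only one measured step touches that same carbon: a 1.1-fold higher number from compound 2 to compound 3 (0.04 log units; within the scatter), which puts hydrogen in place of methoxy. Within the data shown here, no chloro compound has been measured, so this is thin evidence, and no step beyond the scatter is expected in this assay. The expected change is small, an estimated 1.2-fold lower number from compound 3 to compound 4 (0.08 log units; within the scatter). The estimate for compound 4 is 28000 nM, with an expected range of 13000 nM to 60000 nM.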

Compound 4, half-maximal inhibitory concentration: 25000 nM
Beside the measured number, compound 4's estimate is 1.1-fold (0.05 log units) above it; low and high end bracket the measured number.
By their numbers in this assay, from the lowest: compounds 4, 2, 3 and 1 (each within the scatter of the next, the first and the last beyond it).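

In this assay, chloro on this aromatic carbon gives a 1.4-fold lower number from compound 3 to compound 4 (0.13 log units; within the scatter), and with methoxy as the starting group it gives a 1.2-fold lower number from compound 2 to compound 4 (0.09 log units; within the scatter), so hydrogen, methoxy and chloro all lie within the scatter of one another here. Within the data shown here, the one step that passes beyond the scatter is a 2.5-fold lower number from compound 1 to compound 4 (0.40 log units; beyond the scatter), a modest change that swaps 2-phenylethenyl for 1-(4-chlorophenyl)ethenyl. No measurement offered here explains these steps. From the compounds shown here alone, whether an amine, a carboxylic acid or a longer chain on this carbon would move the number beyond the scatter remains open.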